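Quinazoline series: para trifluoromethyl on the anilino ring

The source may hold more compounds than are shown below. What is called first, only, known or untested is meant among the compounds shown, and "the series" means these compounds.

Measured compounds:
compound 1 `FC(F)(F)c1ccc(CSc2nc(Nc3ccccc3Cl)c3ccccc3n2)cc1`, 20400 nM
compound 2 `COc1ccccc1Nc1nc(SCc2ccc(C(F)(F)F)cc2)nc2ccccc12`, 14100 nM
compound 3 `Fc1ccc(Nc2nc(SCc3ccc(C(F)(F)F)cc3)nc3ccccc23)cc1`, 7070 nM

All three share one core and one benzylthio arm and differ only on the anilino ring. In a functional assay on PC-3 cells (Homo sapiens) for cytotoxicity, read by MTT assay, with a stated time of 72 h (on this read-out higher numbers stand for weaker inhibition and lower numbers for stronger inhibition), compound 3 gives the lowest of the three numbers; the step of a 2.9-fold lower number from compound 1 to compound 3 (0.46 log units; beyond the scatter) is beyond the scatter, whereas a 2.0-fold lower number from compound 2 to compound 3 (0.30 log units; within the scatter) is not, so compound 3 and compound 2 cannot be separated on these numbers.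

Compound 4 `FC(F)(F)c1ccc(CSc2nc(Nc3ccc(C(F)(F)F)cc3)c3ccccc3n2)cc1` is not yet measured. Relative to compound 3 the change is trifluoromethyl in place of fluoro on an aromatic carbon. Among the measured compounds shown here, no measured step repeats this exact swap; the steps that touch the same ring are a 2.9-fold lower number from compound 1 to compound 3 (0.46 log units; beyond the scatter) and a 2.0-fold lower number from compound 2 to compound 3 (0.30 log units; within the scatter), both small, and the smaller one changes the position of the substituent rather than its identity alone. The three anilino variations span a narrow band, so the expectation for compound 4 is a step of at most modest size in this assay, with no clear direction. The estimated value for compound 4 is 8000 nM, within 2500 nM to 25000 nM, corresponding to an expected step of a 1.1-fold higher number from compound 3 to compound 4 (0.05 log units; within the scatter).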

Compound 4, half-maximal inhibitory concentration: 7880 nM
Estimate against measurement, compound 4: 1.0-fold (0.01 log units) above; low and high end bracket the measured number.
By their numbers in this assay, from the lowest: compounds 3, 4, 2 and 1 (each within the scatter of the next, the first and the last beyond it).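

In this assay, trifluoromethyl in place of fluoro on this aromatic carbon, para to a large group, gives a 1.1-fold higher number from compound 3 to compound 4 (0.05 log units; within the scatter), so 4 heavy atoms in place of 1 leave no readable change and compound 3 and compound 4 cannot be separated. Compound 4 repeats the pattern of compound 3 against the other anilino rings: a 2.6-fold lower number from compound 1 to compound 4 (0.41 log units; beyond the scatter) lies beyond the scatter, whereas a 1.8-fold lower number from compound 2 to compound 4 (0.25 log units; within the scatter) lies within it. No measurement at hand accounts for this result.

Still open, on these data alone, is whether an amine, a carboxylic acid or a longer alkyl chain on this aromatic carbon would give a step beyond the scatter from compound 4. Also open, as far as these compounds go, is whether the same swap reads alike with another arm on the shared core.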